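Methoxy for methyl on a benzothiazole series in MT4 cytotoxicity

The source may hold more compounds than are shown below. What is called first, only, known or untested is meant among the compounds shown, and "the series" means these compounds.

Compound 1, `Cc1ccc2nc(NN)sc2c1`: 4.52 ug/mL
Compound 2, `COc1ccc2nc(NN)sc2c1`: 14.8 ug/mL
Compound 3, `Cc1ccc2nc(Nn3c(-c4ccc(Cl)cc4)nnc3-c3cccnc3)sc2c1`: 75.5 ug/mL

The three measured compounds were tested in an ADME assay on MT4 cells (Homo sapiens) for cytotoxicity, read by MTT assay, with a stated time of 5 days; a lower number here means that less compound is tolerated, a higher number that more compound is tolerated. Compound 1 gives 4.52 ug/mL in this assay. Compound 2 differs from compound 1 by methoxy in place of methyl on an aromatic carbon, and this change gave a 3.3-fold higher number from compound 1 to compound 2 (0.52 log units; beyond the scatter). Compound 3, which carries a far larger group on the same core, gives 75.5 ug/mL; how its core differs from that of compound 1 is not broken down here.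

Compound 4, `COc1ccc2nc(Nn3c(-c4ccc(Cl)cc4)nnc3-c3cccnc3)sc2c1`, has not yet been measured. It differs from compound 3 by methoxy in place of methyl on an aromatic carbon, the same change that separates compound 2 from compound 1. Because that earlier change produced a 3.3-fold higher number from compound 1 to compound 2 (0.52 log units; beyond the scatter), a step of similar size is expected here, so the author expects a 2.0-fold higher number from compound 3 to compound 4 (0.30 log units; within the scatter) for compound 4. Compound 4 is thus estimated at 150 ug/mL in this assay, with a likely range from 60 ug/mL to 350 ug/mL; since compound 3 already tolerates a large amount, the assay may report only a limit.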

Compound 4, half-maximal cytotoxic concentration: 66.9 ug/mL
Beside the measured number, compound 4's estimate is 2.2-fold (0.35 log units) above it; measured number inside the range.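

In this assay, methoxy in place of methyl on an aromatic carbon gave a 1.1-fold lower number from compound 3 to compound 4 (0.05 log units; within the scatter), so on the core of compound 3 the swap leaves no readable change. The same swap therefore did not carry over in size from the core of compound 1 to the core of compound 3: the same change on two cores in this assay, a 3.3-fold higher number (0.52 log units; beyond the scatter) from compound 1 to compound 2 and a 1.1-fold lower number (0.05 log units; within the scatter) from compound 3 to compound 4, 3.7-fold (0.57 log units) apart, beyond the scatter of two such steps. Among these compounds, this shows that the size of the step cannot be assumed to transfer from one core to the other, but with only two pairs it does not show which feature of the larger compounds is responsible, nor how the swap would behave on any further core.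

From the compounds shown here alone, it remains open whether an ethoxy or an amine on that same aromatic carbon would follow the step seen on the smaller compounds or the one seen on the larger compounds. Going by these compounds, it is also open whether the outcome would hold if the chlorine of compound 3 gave way to a nitrile.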